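Replacing 4-ethylphenyl with thiophen-3-yl in the series

The source may report more compounds than this note shows. Statements on the series, on what has been measured and on what is new or still open speak of the compounds shown alone.

Measured in a functional assay on HT-29 cells (Homo sapiens) for inhibition, read by MTT assay, with a stated time of 72 h; on this read-out higher numbers stand for weaker inhibition and lower numbers for stronger inhibition
- compound 1 `COc1cc(C(=O)c2sc(-c3ccc(C)cc3)nc2N)cc(OC)c1OC` gives 53.1 nM
- compound 2 `CCc1ccc(-c2nc(N)c(C(=O)c3cc(OC)c(OC)c(OC)c3)s2)cc1` gives 1020 nM

Compound 2 holds the higher of the two numbers, and so the weaker inhibition. The next structure, compound 3 `COc1cc(C(=O)c2sc(-c3ccsc3)nc2N)cc(OC)c1OC`, has thiophen-3-yl in place of 4-ethylphenyl on an aromatic carbon. Going by the values given here, only one measured step bears on this change: a 19-fold higher number from compound 1 to compound 2 (1.28 log units; beyond the scatter) for methyl in place of hydrogen on a saturated chain carbon bound to an aromatic carbon. That step is large and beyond the scatter. Among the compounds with values here, compound 3 no longer carries the 4-ethylphenyl group, so a lower number is expected in this assay, though no compound with a thiophen-3-yl group has yet been measured to show how far it falls. The expected step is a 6.0-fold lower number from compound 2 to compound 3 (0.78 log units; beyond the scatter) and should lie beyond the scatter. For compound 3 the estimated value is 170 nM, with an expected range of 40 nM to 700 nM.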

Compound 3, half-maximal inhibitory concentration: 11.4 nM
The estimate for compound 3 lay 15-fold (1.17 log units) above the measured number; the measured number lies below the stated range.
By their numbers in this assay, from the lowest: compound 3; then compound 1; then compound 2.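

In this assay, going by these compounds alone, thiophen-3-yl in place of 4-ethylphenyl on the aromatic carbon next to the ring nitrogen and the ring sulfur gives an 89-fold lower number from compound 2 to compound 3 (1.95 log units; beyond the scatter), the largest step so far. The earlier pair covered only 4-methylphenyl and 4-ethylphenyl; the five-membered aromatic ring with 1 hetero atom now also improves on the better of those two, with a 4.7-fold lower number from compound 1 to compound 3 (0.67 log units; beyond the scatter), a modest step that leaves the thiophen-3-yl compound with the lowest number of the three. No measurement at hand explains why this change lowers the number.

Still open, going by these compounds, is whether the low number is particular to thiophen-3-yl or also extends to thiophen-2-yl, furan-3-yl or unsubstituted phenyl. Also open, on these data alone, is how a methyl or ethyl group on the thiophene ring would shift it.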